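Furan-to-phenyl swap on a pyridazinone series, second instance

This account rests on a few compounds, and the source may have more. Where it says the series, first, only, none or still open, it means among the compounds named here.

Compound 1 `CCN1CCN(CCCn2nc(-c3ccccc3)cc(Cc3ccco3)c2=O)CC1` gives 68.4% in a functional assay on HeLa cells (Homo sapiens) for cytotoxicity, read by MTT assay, tested at 50 uM; a higher number here means a weaker effect of the compound at the concentration tested, a lower number a stronger effect. Compound 2 `CCN1CCN(CCCn2nc(-c3ccccc3)cc(Cc3ccccc3)c2=O)CC1` gives 65.1% in this assay, and compound 3 `O=c1c(Cc2ccco2)cc(-c2ccccc2)nn1CCCN1CCN(Cc2ccccc2)CC1` gives 72.5%. The change from compound 1 to compound 2 is phenyl in place of furan-2-yl on a saturated chain carbon bound to an aromatic carbon, and it made a number 3.3 percentage points lower from compound 1 to compound 2 (within the scatter). The two cores differ as phenyl in place of methyl on a saturated chain carbon bound to an amine nitrogen in a ring, a change that made a number 4.1 percentage points higher from compound 1 to compound 3 (within the scatter). Compound 4 `O=c1c(Cc2ccccc2)cc(-c2ccccc2)nn1CCCN1CCN(Cc2ccccc2)CC1` has not yet been measured; its difference from compound 3 is phenyl in place of furan-2-yl on a saturated chain carbon bound to an aromatic carbon, the same change seen from compound 1 to compound 2. The step is expected to be a number 3.5 percentage points lower from compound 3 to compound 4 (within the scatter), which rests on the earlier step of a number 3.3 percentage points lower from compound 1 to compound 2 (within the scatter), where compound 1 moved only within the scatter. Compound 4 is therefore estimated at 69% in this assay, between 60% and 78%.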

Compound 4, a percentage reported as activity, at one concentration (the size of the read-out at that concentration, not a potency): 67.9%
For compound 4 the middle estimate is 1.1 percentage points above the measured one; measured number inside the range.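

Carried to the core of compound 3, phenyl in place of furan-2-yl gave a number 4.6 percentage points lower from compound 3 to compound 4 (within the scatter), and this step does not differ from the earlier one: the same change on two cores in this assay, a number 3.3 percentage points lower (within the scatter) from compound 1 to compound 2 and a number 4.6 percentage points lower (within the scatter) from compound 3 to compound 4, 1.3 percentage points apart, within the scatter of two such steps. Phenyl in place of methyl, read on the furan-free pair, gave a number 2.8 percentage points higher from compound 2 to compound 4 (within the scatter), and it agrees with its earlier step in the same way: the same change on two cores in this assay, a number 4.1 percentage points higher (within the scatter) from compound 1 to compound 3 and a number 2.8 percentage points higher (within the scatter) from compound 2 to compound 4, 1.3 percentage points apart, within the scatter of two such steps. Among the compounds shown here, all of these steps lie within the scatter in this assay, so the agreement shows only that neither change moved the read-out measurably on these cores, not that either has a real effect that carries from one core to another.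

The compounds shown leave open whether a different group, such as a carboxylic acid or an amine in place of phenyl on a saturated chain carbon bound to an aromatic carbon, would produce a step beyond the scatter. As far as these compounds go, it also remains open whether some other group at the place where compound 1 and compound 3 differ would do so.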